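Hydroxymethyl for hydroxy: step from compound 2 to compound 3

This account rests on a few compounds, and the source may have more. Where it says the series, first, only, none or still open, it means among the compounds named here.

Measured compounds:
Compound 1 `CC1(C)OC(=O)C2(C(=O)O1)[C@@H](c1ccc(-c3ccc(-c4ccc(O)cc4)cc3)cc1)CC(=O)C[C@H]2c1ccccc1`, a limit only in a functional assay on K562 cells (Homo sapiens) for activation, read by annexin V staining, with a stated time of 48 h; on this read-out lower numbers stand for an effect already at smaller amounts and higher numbers for an effect only at larger amounts of compound: > 100000 nM
Compound 2 `Oc1ccc(-c2cc(O)cc(O)c2)cc1`, a limit only: > 80000 nM

Where compound 2 stands: in this assay compound 2 gives > 80000 nM, which is a limit of the assay and not a number. Compound 1 also sits at a limit, (the limit of > 100000 nM in this assay, at which 1 of the 2 values shown sits). Within the data shown here, both values shown are therefore limits, and no step between two measured compounds is available; no measured size or direction of any change can be read from them.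

Compound 3 `OCc1ccc(-c2cc(O)cc(O)c2)cc1` differs from compound 2 by hydroxymethyl in place of hydroxy on an aromatic carbon. With compound 2 at the limit (the limit of > 80000 nM in this assay, at which 1 of the 2 values shown sits), there is no number from which a shift up or down could be counted. The step from compound 2 to compound 3 is expected to be a step that the limit leaves unreadable from compound 2 to compound 3, that is none beyond the scatter. Compound 3 is accordingly expected at about 100000 nM, within a range of 30000 nM to 300000 nM, and most probably the assay will again report only a limit for compound 3.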

Compound 3, concentration for half-maximal activity: > 80000 nM
Compound 3: only a limit was reported; the forecaster's own chance of this, stated with the estimate: 85%; the middle value is on the limit's open side.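

Compound 2 and compound 3 each give only a limit in this assay, and the step between them cannot be read. The compounds shown leave open at what concentration any of them reaches half-maximal activity in this assay, and whether hydroxymethyl in place of hydroxy on an aromatic carbon alters that read-out at all.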